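A Methyl Added to a Compound at the Assay Limit

The compounds below may be only part of what the source reports. "The series", "measured", "known", "first", "only" and "open" are said of these compounds alone.

- Compound 1 `NC(=O)c1ccccc1NC(=O)COc1ccccc1`: 57.4%
- Compound 2 `NC(=O)c1ccccc1NC(=O)COc1cccc(Cl)c1Cl`: < 10%, a limit and not a number
- Compound 3 `Cc1ccc(NC(=O)COc2ccccc2)c(C(N)=O)c1`: 72%

All three results come from a functional assay on K562 cells (Homo sapiens) for inhibition, read by trypan blue exclusion, with a stated time of 24 h, tested at 10 uM; on this read-out lower numbers stand for less inhibition of growth and higher numbers for more inhibition of growth at the one concentration tested. Compound 2 gives only a limit, < 10%, so its true position is not known. It is the one result in the set described by the limit of < 10% in this assay, at which 1 of the 3 values shown sits.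

Compound 4 `Cc1ccc(NC(=O)COc2cccc(Cl)c2Cl)c(C(N)=O)c1` is compound 2 with a single structural change: methyl in place of hydrogen on an aromatic carbon. In words, a methyl takes the place of a hydrogen on an aromatic carbon, meta to a carbamoyl group and para to a large group.

Within the data shown here, one measured step bears on this change. The same swap, at the same place, was measured on a pair without the chlorines: a number 14.6 percentage points higher from compound 1 to compound 3 (beyond the scatter). Among the measured compounds shown here, this is only one step, and it was measured well away from the limit, so it may not carry over in full. A modest upward step of similar size is still the best expectation in this assay, and the result could also stay at the limit.

The expected change is a number at least 5 percentage points higher from compound 2 to compound 4 (that floor lies within the scatter).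

Compound 4 is estimated at 15%, with an expected range of 4% to 32%.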

Compound 4, percent growth inhibition at one concentration: 30.8%
Compound 4: the middle estimate sits 15.8 percentage points below what was measured, and the stated range covers the measured number.
By their numbers in this assay, from the lowest: compound 4; then compound 1; then compound 3. At a limit, below all of these: compound 2.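

In this assay, methyl in place of hydrogen on this aromatic carbon, meta to a carbamoyl group and para to a large group, now gives an upward step on a second core, the one carrying the two chlorines: a number at least 20.8 percentage points higher from compound 2 to compound 4 (beyond the scatter). The earlier evidence was a single step on the core without chlorines, a number 14.6 percentage points higher from compound 1 to compound 3 (beyond the scatter), so the direction of this change now rests on two cores rather than one, and the new step starts from a compound that could be placed only at a limit. Whether the step is larger on one core than on the other cannot be said, since compound 2 is reported only as a limit: the same change on two cores in this assay, a number 14.6 percentage points higher (beyond the scatter) from compound 1 to compound 3 and a number at least 20.8 percentage points higher (beyond the scatter) from compound 2 to compound 4; the limit leaves it open whether they differ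

The compounds shown leave open whether a longer chain at this position, such as ethyl, or a different group there, such as an amine or a carboxylic acid, would move the read-out in the same direction. Whether the same methyl would also give an upward step on any core beyond these two remains an open question.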